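This account rests on a few compounds, and the source may have more. Where it says the series, first, only, none or still open, it means among the compounds named here.

Compound 1 `c1coc(-c2ccccc2OCC2=NCCN2)c1` is one of three close relatives whose cores differ only in the five-membered ring carried on the aromatic carbon. In a functional assay for activation of Alpha-1A adrenergic receptor (Homo sapiens), read by calcium flux (on this read-out higher numbers stand for an effect only at larger amounts of compound and lower numbers for an effect already at smaller amounts), compound 1 gives 1.26 nM; compound 2 `c1c[nH]c(-c2ccccc2OCC2=NCCN2)c1` gives 1.26 nM, and the pair sits level, together the highest of the three numbers, as no change at the digits printed from compound 1 to compound 2 (within the scatter) shows. Compound 3 `c1ccc(-c2ccsc2)c(OCC2=NCCN2)c1` gives 0.251 nM, so that a 5.0-fold lower number from compound 1 to compound 3 (0.70 log units; beyond the scatter) and a 5.0-fold lower number from compound 2 to compound 3 (0.70 log units; beyond the scatter) are both modest steps beyond the scatter. Compound 4 `Cc1csc(-c2ccccc2OCC2=NCCN2)n1` is not yet measured; its change from compound 1 is 4-methyl-1,3-thiazol-2-yl in place of furan-2-yl on an aromatic carbon. Only the two steps to compound 3 bear on a ring swap of this kind, and neither involves the entering ring, so compound 4 is expected to lie near compound 1 with a 1.3-fold higher number from compound 1 to compound 4 (0.10 log units; within the scatter), estimated at 1.6 nM within 0.4 nM to 6 nM.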

Compound 4, half-maximal effective concentration: 25.1 nM
Compound 4: the middle estimate sits 16-fold (1.20 log units) below what was measured, outside the stated range (above it).
By their numbers in this assay, from the lowest: compound 3; then compounds 1 and 2 (each within the scatter of the next); then compound 4.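

In this assay, this position proves far less permissive than the earlier ring swaps suggested, as 4-methyl-1,3-thiazol-2-yl brings large steps (a 20-fold higher number from compound 1 to compound 4 (1.30 log units; beyond the scatter); a 20-fold higher number from compound 2 to compound 4 (1.30 log units; beyond the scatter); a 100-fold higher number from compound 3 to compound 4 (2.00 log units; beyond the scatter)). This change adds a second ring hetero atom and a methyl group at once, so the compounds cannot divide the step between them. No measurement given here accounts for its size. Open, on these data alone, is whether the rise follows the ring nitrogen or the methyl, which a 1,3-thiazol-2-yl without the methyl, or a 4-methylthiophen-2-yl, would separate.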